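The source may hold more compounds than are shown below. What is called first, only, known or untested is meant among the compounds shown, and "the series" means these compounds.

Measured so far:
- compound 1, `O=C(O)[C@H]1NC[C@@H](O)[C@H](O)[C@H]1O`: 6.3%
- compound 2, `O=C(O)[C@H]1NC[C@@H](O)[C@H](O)[C@@H]1O`: 42%
- compound 3, `O=C(O)[C@@H]1NC[C@H](O)[C@@H](O)[C@@H]1O`: 5.4%

In an assay on isolated protein for inhibition of cytosolic endo-beta-N-acetylglucosaminidase (Homo sapiens), tested at 1000 uM (on this read-out higher numbers stand for more inhibition at the one concentration tested (going by the name of the read-out) and lower numbers for less inhibition), compound 3 gives the lowest of the three numbers, with compound 1 within the scatter of it and compound 2 well apart. Compound 4, `O=C(O)[C@@H]1NC[C@H](O)[C@H](O)[C@H]1O`, is not yet measured; it differs from compound 3 as follows: the two compounds have the same atoms and bonds and differ only in configuration as drawn: 2 of 4 stereo elements differ; a stereocentre at a saturated ring carbon is drawn R in compound 3 and S in compound 4; a stereocentre at a saturated ring carbon is drawn R in compound 3 and S in compound 4.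

Three measured steps, all pure changes of configuration, bear on this. a number 0.9 percentage points lower from compound 1 to compound 3 (within the scatter), so full inversion of all centres left the number unchanged. a number 35.7 percentage points higher from compound 1 to compound 2 (beyond the scatter), and a number 36.6 percentage points lower from compound 2 to compound 3 (beyond the scatter), so one or three inversions moved the number by a large amount in either direction. Configuration alone can thus carry a large effect in this assay, but it need not; no rule for two inversions can be drawn from these three compounds. A moderate rise from the low value of compound 3 is expected for compound 4, about a number 9.6 percentage points higher from compound 3 to compound 4 (within the scatter), with wide uncertainty.

Compound 4 is expected to give about 15% in this assay, between 3% and 45%.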

Compound 4, a percentage reported as inhibition, at one concentration (the size of the read-out at that concentration, not a potency): 39%
Compound 4: middle estimate off by 24 percentage points, on the low side; low and high end bracket the measured number.
By their numbers in this assay, from the lowest: compounds 3 and 1 (each within the scatter of the next); then compounds 4 and 2 (each within the scatter of the next).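

In this assay, two differing centres are enough for a large change, as shown by a number 33.6 percentage points higher from compound 3 to compound 4 (beyond the scatter) and by a number 32.7 percentage points higher from compound 1 to compound 4 (beyond the scatter). Three differing centres need not change the number at all, as shown by a number 3 percentage points lower from compound 2 to compound 4 (within the scatter), although the three-centre step between compound 2 and compound 3 was large, so the count of differing centres does not set the size of a step within this set. The four compounds now fall into a low pair, compounds 1 and 3, and a high pair, compounds 2 and 4, and the rise into the high pair can occur with configuration as the only change: the fact that compounds 3 and 4 differ only in the configuration as drawn

Going by these compounds, it remains open which of the two centres that differ between compound 3 and compound 4 carries the step, or whether both are needed. Also open, on these data alone, is whether a primary amide in place of the carboxylic acid would keep the inhibition seen with compounds 2 and 4.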